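A Hydroxy Group Added to Compound 2

A few compounds are considered here, and "the series" means these few. Any claim that something is new, unique, unknown or untested is made for them only; others in the source may bear on it.

Compound 1 `COc1cc(/C=C/C(=O)c2ccccc2-c2ccc(F)cc2)ccc1O` gives 2500 nM
Compound 2 `COc1ccc(C(=O)/C=C/c2ccccc2-c2ccc(F)cc2)cc1` gives 9000 nM
Compound 3 `COc1ccc(C(=O)/C=C/c2ccccc2-c2ccc(F)nc2)cc1` gives 13000 nM

These values come from a functional assay on CNE-2 cells (Homo sapiens) for antiproliferative activity, read by sulforhodamine B assay, with a stated time of 48 h; on this read-out lower numbers stand for stronger inhibition and higher numbers for weaker inhibition. Compound 2 lies within the scatter of compound 3, and both numbers stand clearly higher than that of compound 1. Compound 4 `COc1ccc(C(=O)/C=C/c2ccccc2-c2ccc(F)cc2)cc1O` departs from compound 2 by hydroxy in place of hydrogen on an aromatic carbon, which is hydroxy in place of hydrogen on an aromatic carbon. For the measured compounds named here, the only measured single change, a 1.4-fold higher number from compound 2 to compound 3 (0.16 log units; within the scatter), involves a different part of the molecule and says nothing directly about a hydroxy group. The nearest hint is compound 1 at 2500 nM, which carries both hydroxy and methoxy groups but differs from compound 2 in more than one place. A moderate fall in the number in this assay is therefore expected, though on thin evidence. The expected change is a 3.2-fold lower number from compound 2 to compound 4 (0.51 log units; beyond the scatter). The estimated value for compound 4 is 2800 nM, with an expected range from 600 nM to 10000 nM.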

Compound 4, half-maximal inhibitory concentration: 750 nM
Estimate against measurement, compound 4: 3.7-fold (0.57 log units) above, within the range that was stated.
By their numbers in this assay, from the lowest: compound 4; then compound 1; then compounds 2 and 3 (each within the scatter of the next).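

In this assay, hydroxy in place of hydrogen on an aromatic carbon gives a 12-fold lower number from compound 2 to compound 4 (1.08 log units; beyond the scatter), a large step at a position, ortho to a methoxy group and meta to a large group, where no single change had been shown before. For the compounds shown here, the only earlier single change, 6-fluoropyridin-3-yl in place of 4-fluorophenyl, gave a 1.4-fold higher number from compound 2 to compound 3 (0.16 log units; within the scatter), so this hydroxy step is the first single change here to lie beyond the scatter. No evidence at hand gives a reason for the size of this step.

The compounds shown leave open whether an amine, a fluorine or a second methoxy group in the same place would give a comparable step, or whether the step depends on the hydroxy group itself. They also leave open whether the same hydroxy group would produce a similar step on compound 3, which carries the 6-fluoropyridin-3-yl group.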